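Hydrazone Series Against Maltase-Glucoamylase: From Dihydroxyphenyl to Ester

A few compounds are considered here, and "the series" means these few. Any claim that something is new, unique, unknown or untested is made for them only; others in the source may bear on it.

Measured so far:
compound 1, `O=C(N/N=C/c1cccnc1)c1ccc(-c2nc3ccccc3s2)cc1`: "not active" (no number reported)
compound 2, `O=C(N/N=C/c1ccc(O)c(O)c1)c1ccc(-c2nc3ccccc3s2)cc1`: 15100 nM

Two compounds share the same core and differ only in the ring carried on the carbon with a double bond to nitrogen. In an assay on isolated protein for inhibition of Maltase-glucoamylase (Homo sapiens), with a stated time of 15 min (on this read-out higher numbers stand for weaker inhibition and lower numbers for stronger inhibition), compound 1 is reported as "not active" (no number reported) with no number given. In this assay, among the compounds with values here, compound 2 gives 15100 nM, and this is the only number in the set so far, so compound 2 stands alone as the single quantified entry, with compound 1 beside it as an entry without a number.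

Compound 3, `COC(=O)c1ccc(/C=N/NC(=O)c2ccc(-c3nc4ccccc4s3)cc2)cc1`, has not yet been measured in this assay. It differs from compound 2 by 4-(methoxycarbonyl)phenyl in place of 3,4-dihydroxyphenyl on a carbon with a double bond to nitrogen. Within the data shown here, no step between measured compounds is available to calibrate this change, and the sole hydroxyl-free analogue, compound 1, gave no number. The step is therefore expected to go toward weaker inhibition, beyond the usual scatter, as a 4.0-fold higher number from compound 2 to compound 3 (0.60 log units; beyond the scatter). On that basis compound 3 is estimated at 60000 nM in this assay, within a range of 20000 nM to 200000 nM, with a real chance that no number at all is reported.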

Compound 3, half-maximal inhibitory concentration: "not active" (no number reported)
The entry for compound 3 holds no number; no gap can be computed for the estimate.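

Within the data shown here, compound 3, like compound 1, carries no number in this assay, so no step from compound 2 to compound 3 can be read. The compounds shown leave open how much of the value of compound 2 depends on its 3,4-dihydroxyphenyl group. Nothing available bears on the reason for this result.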